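A few compounds are considered here, and "the series" means these few. Any claim that something is new, unique, unknown or untested is made for them only; others in the source may bear on it.

Of the compounds shown here, three have been tested so far in an assay for inhibition of steroid 17-alpha-hydroxylase/17,20 lyase (Homo sapiens), using NADPH, tested at 0.2 uM; on this read-out lower numbers stand for a weaker effect and higher numbers for a stronger effect at the one concentration tested. Compound 1 `CC(C)C(O)(c1ccc(-c2ccsc2)cc1)c1c[nH]cn1` gives 7% in this assay. Compound 2 `CCC(c1cc(-c2ccc(F)c(F)c2)cs1)n1ccnc1` gives 17% in this assay, the highest of the three numbers, although the value of compound 1 sits within the usual scatter of that number, so the two cannot be told apart. Compound 3 `c1cncc(-c2ccc(Cn3ccnc3)cc2)c1` gives 2% in this assay, a number that lies beyond the scatter below compound 2.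

The next compound to be measured is compound 4 `Fc1ccc(-c2csc(Cn3ccnc3)c2)cc1F`. Compared with compound 2, the change is a single one: hydrogen in place of ethyl on a saturated chain carbon bound to an aromatic carbon and an aromatic nitrogen. Among the measured compounds shown here, no step between two measured compounds shows what such a change does here, so the expectation rests on the spread of the numbers seen so far, which runs from the value of compound 3 up to that of compound 2. For compound 4, a small downward step a number 7 percentage points lower from compound 2 to compound 4 (within the scatter) is expected in this assay, most likely staying within the scatter. Compound 4 is therefore estimated to give 10% in this assay, with a range from 0% to 25%.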

Compound 4, a percentage reported as inhibition, at one concentration (the size of the read-out at that concentration, not a potency): 7%
For compound 4 the middle estimate is 3 percentage points above the measured one; measured number inside the range.
By their numbers in this assay, from the lowest: compounds 3, 1, 4 and 2 (each within the scatter of the next, the first and the last beyond it).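

In this assay, among the compounds shown here, the pair gives the first direct look at this position: hydrogen in place of ethyl on a saturated chain carbon bound to an aromatic carbon and an aromatic nitrogen gives a number 10 percentage points lower from compound 2 to compound 4 (within the scatter), so the two compounds cannot be told apart. The ethyl group is therefore not shown to matter for this read-out, although a single pair at one concentration cannot show that it never does. Nothing available here offers an explanation for this result.

The compounds shown leave open whether a methyl group, a hydroxyl group or a longer chain such as butyl on this same carbon would give a number beyond the scatter of compound 2. Also open, going by these compounds, is whether compound 2 and compound 4 would separate, with a stronger effect for one of them, if tested at other concentrations.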